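Trimming the Acid Chain on a Shared Core

The source may hold more compounds than are shown below. What is called first, only, known or untested is meant among the compounds shown, and "the series" means these compounds.

Compound 1 `Cc1ccc(NC(=O)CC(=O)O)c2ccn(Cc3ccc(O)c(C(C)C)c3)c12` and compound 2 `Cc1cc2c(NC(=O)CC(=O)O)cccc2n1Cc1ccc(O)c(C(C)C)c1` share a core and carry the same acid-bearing side chain. In an assay on CV-1 cells for agonist activity at thyroid hormone receptor beta (Homo sapiens), read by reporter gene assay, with a stated time of 10 h (on this read-out lower numbers stand for an effect already at smaller amounts and higher numbers for an effect only at larger amounts of compound), compound 2 gives 1700 nM and compound 1 gives 3100 nM; these two values lie within the usual scatter of each other, so neither compound stands apart from the other. Compound 3 `Cc1cc2c(NC(=O)C(=O)O)cccc2n1Cc1ccc(O)c(C(C)C)c1` is the next step: the difference carboxy in place of carboxymethyl on a carbonyl carbon separates it from compound 2. Among the measured compounds shown here, no measured pair shows this change, so its size cannot be read from the data. The step of a 1.2-fold higher number from compound 2 to compound 3 (0.07 log units; within the scatter) is expected to stay within the scatter. Compound 3 is estimated at 2000 nM, in a range from 600 nM to 7000 nM.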

Compound 3, half-maximal effective concentration: 590 nM
Compound 3: the middle estimate sits 3.4-fold (0.53 log units) above what was measured; measured number below the stated range.
By their numbers in this assay, from the lowest: compound 3; then compounds 2 and 1 (each within the scatter of the next).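

Trimming the chain on the carbonyl carbon, with carboxy in place of carboxymethyl, gives a 2.9-fold lower number from compound 2 to compound 3 (0.46 log units; beyond the scatter) in this assay, so at this position the length of the acid chain can shift the number beyond the scatter. Compound 1 and compound 2 could not show this, as they carry the same chain. No measurement here explains this shift.

Going by these compounds, it remains open how a longer chain such as carboxyethyl, or an amine in place of the carboxylic acid, would behave. On these data alone, whether the shorter chain brings the same shift on the core of compound 1 is also open.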